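The compounds below may be only part of what the source reports. "The series", "measured", "known", "first", "only" and "open" are said of these compounds alone.

Series notes. Going by the values given here, compound 1 `NC[C@@H]1CCCc2cc(S(=O)(=O)Cc3ccccc3)ccc21` is one of two compounds measured in an assay on isolated protein for displacement of a labelled ligand from 5-hydroxytryptamine receptor 6 (Homo sapiens); a lower number here means a stronger inhibitor, a higher number a weaker inhibitor; in this assay compound 1 gives 158 nM. Compound 2 `O=C(NC[C@@H]1CCCc2cc(S(=O)(=O)c3cccc(F)c3)ccc21)c1ncc[nH]1` carries a different sulfonyl aryl group and an amide on the aminomethyl arm; in this assay compound 2 gives 15.9 nM, the lowest of the two numbers and beyond the scatter from compound 1. The two compounds differ in more than one place, so nothing more is read from that pair than the two values themselves.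

Compound 3 `CN(C)C(=O)NC[C@@H]1CCCc2cc(S(=O)(=O)c3cccc(F)c3)ccc21` has not yet been measured. It differs from compound 2 by dimethylamino in place of 1H-imidazol-2-yl on a carbonyl carbon, that is, a dimethylcarbamoyl in place of an (1H-imidazol-2-yl)carbonyl on the amide nitrogen. Among the compounds with values here, no measured pair shows such a change, so the direction rests on expectation only: a modest loss in this assay is estimated, with the step from compound 2 to compound 3 expected at a 2.5-fold higher number from compound 2 to compound 3 (0.40 log units; beyond the scatter). For compound 3 the expected value is 40 nM, with a range from 12 nM to 130 nM.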

Compound 3, inhibition constant: 2.51 nM
For compound 3 the middle estimate is 16-fold (1.20 log units) above the measured one; the whole stated range lies above it.
By their numbers in this assay, from the lowest: compound 3; then compound 2; then compound 1.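

At this position, on a carbonyl carbon whose other neighbour is an amide-type nitrogen, the 1H-imidazol-2-yl group is not required for a low number in this assay: replacing it with dimethylamino gives a 6.3-fold lower number from compound 2 to compound 3 (0.80 log units; beyond the scatter). The entering group has no ring, no hydrogen-bond donor and fewer heavy atoms, so neither the five-membered aromatic ring nor its donor is needed to reach this level on the present arm. Nothing available here accounts for the step.

Going by these compounds, whether a similar number would follow from methylamino, diethylamino or a pyrrolidine ring on the same carbonyl remains open, so the step cannot yet be tied to dimethylamino in particular. Compound 1 differs from both other compounds in more than one place, so its comparisons cannot be read as single changes.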